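The source may hold more compounds than are shown below. What is called first, only, known or untested is meant among the compounds shown, and "the series" means these compounds.

Working notes on the series

Compound 1 `Cc1cc(Cl)c2c(c1O)C(=O)C=CC2=O` is the reference point. Among the compounds with values here, in a functional assay on HeLa cells (Homo sapiens) for cytotoxicity, read by XTT assay, with a stated time of 24 h (on this read-out lower numbers stand for stronger inhibition and higher numbers for weaker inhibition), compound 1 gives 10100 nM, the lowest of the two numbers known so far. Within the data shown here, compound 2 `CC(=O)Oc1cc(OC(C)=O)c2c(OC(C)=O)cc(C)c(Cl)c2c1OC(C)=O` is the only other measured member; in this assay compound 2 gives 52900 nM, a higher number than that of compound 1 and beyond the usual scatter. Among the measured compounds shown here, no single-point step between the two is available, so their values show only that compound 1 is the more potent of the pair.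

For the measured compounds named here, compound 3 `COc1c(C)cc(Cl)c2c1C(=O)C=CC2=O` is the first one-point variation on compound 1 and is still to be measured in this assay. The change is methyl in place of hydrogen on an oxygen on an aromatic ring, read one bond further out as hydroxy to methoxy. Going by the values given here, no measured step of this kind exists, so the expectation rests on the two values above and the nature of the change alone. Capping the oxygen on the aromatic ring is expected to cost some potency, and the step from compound 1 to compound 3 is estimated at a 2.2-fold higher number from compound 1 to compound 3 (0.34 log units; beyond the scatter) in this assay. Compound 3 is therefore expected to give about 22000 nM in this assay, within a range of 8000 nM to 60000 nM.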

Compound 3, half-maximal inhibitory concentration: 41500 nM
For compound 3 the middle estimate is 1.9-fold (0.28 log units) below the measured one; the measured number falls inside the stated range.
By their numbers in this assay, from the lowest: compound 1; then compounds 3 and 2 (each within the scatter of the next).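

Within the data shown here, the step from hydroxy to methoxy is the first single-point comparison, and it puts a size on a change at this oxygen on an aromatic ring: a 4.1-fold higher number from compound 1 to compound 3 (0.61 log units; beyond the scatter) in this assay. The earlier pair of compounds differed in several places and could not isolate any one of them, whereas this step shows that methyl in place of hydrogen on this oxygen is enough by itself to give a higher number, with the rest of the core of compound 1 unchanged. No measurement available here accounts for the size of this step, so it stands as an observation about one change at one place.

The compounds shown leave open whether the higher number follows from any group on this oxygen or is particular to methyl, and how an ethyl group or a longer chain there, or an amine in place of the hydroxy, would compare with compound 1. From the compounds shown here alone, whether a change of this kind gives a similar step at any other place on the shared core also remains open, as this single step supports no wider pattern.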